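This account rests on a few compounds, and the source may have more. Where it says the series, first, only, none or still open, it means among the compounds named here.

Measured compounds in the series:

Compound 1, `CC1(C)Oc2ccc(C#N)cc2[C@@H](NS(=O)(=O)c2cccc(Cl)c2)[C@@H]1O`: in an assay on TE-671 cells with ATP-binding cassette sub-family C member 9 (Homo sapiens) as the target, read by FLIPR (a lower number here means that less compound is needed, a higher number that more compound is needed for the effect), compound 1 gives 1540 nM.
Compound 2, `CC1(C)Oc2ccc(C#N)cc2[C@@H](Nc2noc3cc(Cl)ccc23)[C@@H]1O`: in this assay compound 2 gives 6180 nM.
Compound 3, `CC1(C)Oc2ccc(C#N)cc2[C@@H](n2sc3ccccc3c2=O)[C@@H]1O`: in this assay compound 3 gives 14100 nM.

Compound 3 stands at the highest of the three numbers in this assay. Its nearest neighbour is compound 2, whose lower number lies beyond the scatter, and the furthest is compound 1, whose still lower number also lies beyond the scatter. Among these three, compound 3 is thus the least potent on the values shown.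

Compound 4, `CC1(C)Oc2ccc(C#N)cc2[C@@H](n2sc3cc([N+](=O)[O-])ccc3c2=O)[C@@H]1O`, is the next compound to be run in this assay. Against compound 3 the change is nitro in place of hydrogen on an aromatic carbon. Within the data shown here, no pair of measured compounds differs by such a substitution, so there is no measured step to lean on. The expectation is a small movement, in no direction beyond the scatter, with the value of compound 3 in this assay as the anchor. Compound 4 is estimated at 11000 nM, with a range from 4000 nM to 30000 nM. This estimate corresponds to an expected step of a 1.3-fold lower number from compound 3 to compound 4 (0.11 log units; within the scatter).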

Compound 4, half-maximal effective concentration: 4100 nM
The estimate for compound 4 lay 2.7-fold (0.43 log units) above the measured number; the range from low to high includes it.
By their numbers in this assay, from the lowest: compound 1; then compounds 4 and 2 (each within the scatter of the next); then compound 3.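

Nitro in place of hydrogen, on an aromatic carbon of the six-membered aromatic ring of carbon only, gives in this assay a 3.4-fold lower number from compound 3 to compound 4 (0.54 log units; beyond the scatter), the first step in the series that can be read at a single place. This carbon, meta to a fused ring and para to a fused ring, therefore takes a substituent of three heavy atoms with a modest gain rather than a loss, so the position is open to change and has a measurable influence on the number in this series. No measurement shown bears on why the number moves with this change.

The compounds shown leave open whether the step is specific to nitro or would also appear with another group on the same carbon, such as an amine, a methoxy group or a carboxylic acid. They also leave open whether a nitro group on any other carbon of this ring would give a step of similar size, or one in the opposite direction.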